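The source may hold more compounds than are shown below. What is called first, only, known or untested is meant among the compounds shown, and "the series" means these compounds.

Measured so far in a functional assay on LNCaP cells (Homo sapiens) for cytotoxicity, read by MTT assay, with a stated time of 72 h; a higher number here means a weaker inhibitor, a lower number a stronger inhibitor:
compound 1 `CC1=C(/C=C/C(=O)/C=C/c2cccc(C#N)c2)C(C)(C)CCC1O` gives 1800 nM
compound 2 `CC1=C(/C=C/C(=O)/C=C/c2cccc([N+](=O)[O-])c2)C(C)(C)CCC1O` gives 2000 nM
compound 3 `COc1cccc(/C=C/C(=O)/C=C/C2=C(C)C(O)CCC2(C)C)c1` gives 4900 nM

Compound 3 stands at the highest number of the three; its nearest neighbour is compound 2, and the steps of a 2.7-fold higher number from compound 1 to compound 3 (0.43 log units; beyond the scatter) and a 2.5-fold higher number from compound 2 to compound 3 (0.39 log units; beyond the scatter) are both modest and both beyond the scatter. Compound 4 `CCOC(OCC)c1cccc(/C=C/C(=O)/C=C/C2=C(C)C(O)CCC2(C)C)c1` differs from compound 3 in one place: diethoxymethyl in place of methoxy on an aromatic carbon. Both measured steps bear on it only loosely, since each swaps the group on this same aromatic carbon; neither replaces methoxy with a larger acetal-like group, so the direction is open. A step no larger than modest is expected in this assay. Compound 4 is estimated at 5500 nM, in the range 2200 nM to 14000 nM, which is expected to mean a 1.1-fold higher number from compound 3 to compound 4 (0.05 log units; within the scatter).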

Compound 4, half-maximal inhibitory concentration: 1800 nM
Compound 4: middle estimate off by 3.1-fold (0.49 log units), on the high side, outside the stated range (below it).
By their numbers in this assay, from the lowest: compounds 1, 4 and 2 (each within the scatter of the next); then compound 3.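

At this aromatic carbon, a 2.7-fold lower number from compound 3 to compound 4 (0.43 log units; beyond the scatter) follows diethoxymethyl in place of methoxy in this assay and shows that a much larger group here need not raise the number; compound 3 alone stands apart. Replacing the electron-neutral description aside, the other swaps give a 1.1-fold lower number from compound 2 to compound 4 (0.05 log units; within the scatter) and no change at the digits printed from compound 1 to compound 4 (within the scatter) so nitrile, nitro and diethoxymethyl cannot be ordered at this position. Nothing available gives a reason for these steps.

On these data alone, whether an amine or a carboxylic acid on this carbon would shift the number beyond the scatter remains open. Also open, as far as these compounds go, is whether dimethoxymethyl or an aldehyde here would match diethoxymethyl.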